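The source may hold more compounds than are shown below. What is called first, only, known or untested is meant among the compounds shown, and "the series" means these compounds.

Series in a functional assay on HEL cells (Homo sapiens) for cytotoxicity; on this read-out higher numbers stand for lower toxicity in this test and lower numbers for higher toxicity in this test:
- Compound 1 `CO[C@@H]1[C@@H](OC)[C@H](c2ccccc2)O[C@@H]2CO[C@@H](c3ccccc3)O[C@@H]12`: "not determined" (no result reported)
- Compound 2 `CO[C@@H]1[C@@H](OC)[C@H](c2ccccc2)O[C@@H]2CO[C@@H](c3ccc(Cl)cc3)O[C@@H]12`: > 50 ug/mL
- Compound 3 `CO[C@@H]1[C@@H](OC)[C@H](c2ccccc2)O[C@@H]2CO[C@@H](c3ccc(C(F)(F)F)cc3)O[C@@H]12`: > 50 ug/mL

Compound 3 gives > 50 ug/mL in this assay, and this is a limit, not a number. Compound 2 gives > 50 ug/mL, which is likewise a limit. Compound 1 gives "not determined" (no result reported) and offers no comparison. The standing of compound 3 is therefore known only as a limit, with no measured number in the series to place it against.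

The next compound is compound 4 `CO[C@@H]1[C@@H](OC)[C@H](c2ccccc2)O[C@@H]2CO[C@@H](c3ccc(-c4ccccc4)cc3)O[C@@H]12`, with phenyl in place of trifluoromethyl on an aromatic carbon.

Within the data shown here, only one measured step bears on this change, a step that the two limits leave unreadable from compound 2 to compound 3, and it has no readable size. It also changes the same aromatic position, but it gives no direction to carry over. The only firm observation is the limit of > 50 ug/mL in this assay, at which 2 of the 3 values shown sit. On that basis, no step beyond the usual scatter is expected in this assay, and no direction can be assigned. A further report of only a limit is the likeliest outcome.

The expected step is a number no higher from compound 3 to compound 4 (the limit leaves the size open).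

For compound 4 the estimated value is 50 ug/mL, with an expected range from 20 ug/mL to 100 ug/mL.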

Compound 4, half-maximal cytotoxic concentration: > 50 ug/mL
Compound 4 gave a limit, no number (the forecaster's own chance of this, stated with the estimate: 75%); the middle value sits exactly at the limit.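

Among these compounds, compound 2, compound 3 and compound 4 are all reported only as limits in this assay, and no step among them can be read. The compounds shown leave open how far each compound's half-maximal cytotoxic concentration lies past its limit, and whether chloro, trifluoromethyl and phenyl differ at all on this read-out.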